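This account rests on a few compounds, and the source may have more. Where it says the series, first, only, none or still open, it means among the compounds named here.

Measured so far in a functional assay on HCT-116 cells (Homo sapiens), read by MTT assay, with a stated time of 72 h; on this read-out higher numbers stand for weaker inhibition and lower numbers for stronger inhibition:
- compound 1 `CNc1ncnc2c1c(-c1ccco1)cn2[C@@H]1O[C@H](CO)[C@@H](O)[C@H]1O`: 230 nM
- compound 2 `CNc1ncnc2c1c(-c1ccsc1)cn2[C@@H]1O[C@H](CO)[C@@H](O)[C@H]1O`: > 20000 nM (a limit)
- compound 3 `C#Cc1cn([C@@H]2O[C@H](CO)[C@@H](O)[C@H]2O)c2ncnc(NC)c12`: > 20000 nM (a limit)

Compound 3 stands at the limit of > 20000 nM in this assay, at which 2 of the 3 values shown sit, so it has a limit and not a number. Compound 4 `C#Cc1cn([C@@H]2O[C@H](CO)[C@@H](O)[C@H]2O)c2ncnc(N(C)C)c12` differs from it by methyl in place of hydrogen on a nitrogen on an aromatic ring, methylamino to dimethylamino. Going by the values given here, no measured step changes that nitrogen. The nearest evidence comes from changes on an aromatic carbon: an at least 86-fold higher number from compound 1 to compound 3 (1.93 log units; beyond the scatter) and an at least 86-fold higher number from compound 1 to compound 2 (1.93 log units; beyond the scatter) are both large, while a step that the two limits leave unreadable from compound 2 to compound 3 cannot be read. They bear on the methyl change only indirectly, and neither suggests a recovery of activity. The expected change is a number no higher from compound 3 to compound 4 (the limit leaves the size open), with none beyond the scatter and no readable direction in this assay. For compound 4 the estimate is 20000 nM, with an expected range of 6000 nM to 40000 nM.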

Compound 4, half-maximal inhibitory concentration: 180 nM
Estimate against measurement, compound 4: 110-fold (2.05 log units) above; the measured number lies below the stated range.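

In this assay, going by these compounds alone, methyl in place of hydrogen on the nitrogen gives an at least 110-fold lower number from compound 3 to compound 4 (2.04 log units; beyond the scatter), so this nitrogen, which no earlier step had changed, can decide the outcome. Within the data shown here, with dimethylamino in place of methylamino, ethynyl on the aromatic carbon is compatible with a measurable number, which the earlier compounds did not show. Compound 3 has only a limit, so the full size of the step stays open: the limit of > 20000 nM in this assay, at which 2 of the 4 values shown sit.

Going by these compounds, it remains open whether the methyl change acts the same way with thiophen-3-yl or furan-2-yl on the aromatic carbon. Also open, on these data alone, is how a longer chain such as ethyl on this nitrogen, or a cyclic amine such as pyrrolidine in its place, would read.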